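Methyl on the shared core: compound 3 to compound 4

The source may hold more compounds than are shown below. What is called first, only, known or untested is meant among the compounds shown, and "the series" means these compounds.

- compound 1 `Cc1nn(C)c2nc(NNC(=O)Nc3cc(Cl)nc(Cl)c3)cc(C3CC3)c12` gives 67700 nM
- compound 2 `Cc1nn(C)c2nc(NNC(=O)Nc3cc(Cl)nc(Cl)c3)cc(-c3ccc(Cl)s3)c12` gives 42100 nM
- compound 3 `Cn1ncc2c(-c3ccc(F)cc3)cc(NNC(=O)Nc3cc(Cl)nc(Cl)c3)nc21` gives 8210 nM

All three values come from a functional assay on HCT-116 cells (Homo sapiens) for cytotoxicity, read by MTT assay, with a stated time of 48 h, in the presence of a further agent that is not named here (on this read-out lower numbers stand for an effect already at smaller amounts and higher numbers for an effect only at larger amounts of compound), and compound 3 has the lowest number of the three, with the other two lying beyond the scatter above it.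

Compound 4 `Cc1nn(C)c2nc(NNC(=O)Nc3cc(Cl)nc(Cl)c3)cc(-c3ccc(F)cc3)c12` is the next case. Its difference from compound 3 is methyl in place of hydrogen on an aromatic carbon and amounts to methyl in place of hydrogen on an aromatic carbon.

Going by the values given here, no measured pair isolates this change. Among the compounds with values here, the only measured step, a 1.6-fold lower number from compound 1 to compound 2 (0.21 log units; within the scatter), lies at another place and stays within the scatter, so it offers no direct guide to the size of the methyl step. Indirect evidence comes from compound 1 at 67700 nM and compound 2 at 42100 nM, since both carry the same methyl and both have higher numbers than compound 3. Each also differs from compound 3 at a second place, so that gap cannot be assigned to the methyl alone. A rise is therefore expected, but a smaller one than that gap.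

The expected size of the change is a 2.2-fold higher number from compound 3 to compound 4 (0.34 log units; beyond the scatter) and it remains uncertain.

For compound 4 the estimated value is 18000 nM with an expected range from 6000 nM to 50000 nM in this assay.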

Compound 4, half-maximal effective concentration: 25200 nM
Compound 4: middle estimate off by 1.4-fold (0.15 log units), on the low side; measured number inside the range.
By their numbers in this assay, from the lowest: compound 3; then compounds 4, 2 and 1 (each within the scatter of the next, the first and the last beyond it).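

Notes on the methyl position: in this assay the methyl on the aromatic carbon of the five-membered aromatic ring now stands alone as the single change, with 4-fluorophenyl held constant (a 3.1-fold higher number from compound 3 to compound 4 (0.49 log units; beyond the scatter)), so this carbon responds to one added heavy atom by a modest step beyond the scatter. With that methyl in place, the neighbouring comparisons on the other aromatic carbon also sharpen: 4-fluorophenyl separates from cyclopropyl beyond the scatter (a 2.7-fold lower number from compound 1 to compound 4 (0.43 log units; beyond the scatter)) but does not separate from 5-chlorothiophen-2-yl, which stays within it (a 1.7-fold lower number from compound 2 to compound 4 (0.22 log units; within the scatter)). No measurement available here speaks to the origin of the methyl step.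

From the compounds shown here alone, whether the methyl step keeps its size when cyclopropyl or 5-chlorothiophen-2-yl replaces 4-fluorophenyl remains open, so the step is so far known for one pair only. Also open, going by these compounds, is how this carbon responds to anything other than hydrogen and methyl, such as an ethyl chain, an amine or a carboxylic acid, and whether any group there gives a lower number than hydrogen does.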